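The compounds below may be only part of what the source reports. "The series", "measured", "known", "first", "only" and "open" are said of these compounds alone.

Compound 1, `NC1=NC2(CCSCC2)N(OCCCOc2cccc(Cl)c2)C(N)=N1`: 1 nM
Compound 2, `CC(C)(C)c1ccc(OCCCON2C(N)=NC(N)=NC23CCSCC3)cc1`: 1 nM

Both compounds were tested in a functional assay on HCT-116 cells (Homo sapiens) for antiproliferative activity, read by MTT assay, with a stated time of 72 h; on this read-out higher numbers stand for weaker inhibition and lower numbers for stronger inhibition. In this assay compound 1 gives 1 nM, and in the same assay compound 2 gives 1 nM. Compound 2 thus stands level with compound 1 at the digits shown, and the two values lie within the scatter of each other, so no order can be drawn between them. Compound 3, `COc1ccc(OCCCON2C(N)=NC(N)=NC23CCSCC3)cc1`, has not yet been measured. It differs from compound 2 in one place: methoxy in place of tert-butyl on an aromatic carbon. Among the measured compounds shown here, no step between the two measured compounds is known, so nothing measured here speaks to this change directly. The two measured compounds share the same core and the same chain to the aromatic ring, and each carries a different group on that ring while giving the same strong value, which suggests that the group on that ring is tolerated. The step of a 2.0-fold higher number from compound 2 to compound 3 (0.30 log units; within the scatter) is therefore expected to be small, a modest weakening at most. On this basis compound 3 is estimated at 2 nM, within a range from 0.5 nM to 10 nM.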

Compound 3, half-maximal inhibitory concentration: 70 nM
Compound 3: middle estimate off by 35-fold (1.54 log units), on the low side; the whole stated range lies below it.
By their numbers in this assay, from the lowest: compounds 1 and 2 (each within the scatter of the next); then compound 3.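

In this assay methoxy in place of tert-butyl on the aromatic carbon gives a 70-fold higher number from compound 2 to compound 3 (1.85 log units; beyond the scatter) and so this position proves far less forgiving than the first two compounds suggested. Changing the aryl group as a whole, with 4-methoxyphenyl in place of 3-chlorophenyl, gives a 70-fold higher number from compound 1 to compound 3 (1.85 log units; beyond the scatter) and thus the same large loss from the other starting point. Among the compounds shown here, of these three compounds only the one carrying methoxy loses strength, so the matching values of compounds 1 and 2 did not mean that any group on the ring would do. Going by these compounds, whether the loss goes with the oxygen of methoxy or with its fewer heavy atoms stays open, and an ethyl group in the same place would help to separate the two. Nothing else available here bears on the reason for the loss.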